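Lengthening an Alkyl Chain on a Shared Core

A few compounds are considered here, and "the series" means these few. Any claim that something is new, unique, unknown or untested is made for them only; others in the source may bear on it.

Compound 3 `CCCCCCSC(=S)N[C@H]1CCOC1=O` belongs to a small set of close relatives built on one core, the others being compound 1 `CCSC(=S)N[C@H]1CCOC1=O` and compound 2 `CCCCSC(=S)N[C@H]1CCOC1=O`. In a functional assay on SMMC-7721 cells (Homo sapiens) for cytotoxicity, read by MTT assay, with a stated time of 72 h (on this read-out higher numbers stand for weaker inhibition and lower numbers for stronger inhibition), compound 1 gives only a limit, > 128000 nM. Compound 2 likewise gives only a limit in this assay, > 128000 nM. Compound 3 also reaches only a limit in this assay, > 128000 nM, so its standing among the three cannot be ordered. Compound 4 `CCCCCCCCSC(=S)N[C@H]1CCOC1=O` differs from compound 3 by ethyl in place of hydrogen on a saturated chain carbon, six bonds along the chain from a sulfur. The earlier steps shown here of the same kind, a step that the two limits leave unreadable from compound 1 to compound 2, a step that the two limits leave unreadable from compound 1 to compound 3 and a step that the two limits leave unreadable from compound 2 to compound 3, cannot be sized because of the limit of > 128000 nM in this assay, at which 3 of the 3 values shown sit. Within the data shown here, with no measured step readable, the expected change is a number no higher from compound 3 to compound 4 (the limit leaves the size open), that is none beyond the scatter. Compound 4 is therefore estimated in this assay at 128000 nM, most likely again as a limit, with a range from 30000 nM to 400000 nM.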

Compound 4, half-maximal inhibitory concentration: 65100 nM
Estimate against measurement, compound 4: 2.0-fold (0.29 log units) above; low and high end bracket the measured number.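

Ethyl in place of hydrogen on a saturated chain carbon, six bonds along the chain from a sulfur, gives the only compound of the four that reads as a number rather than a limit in this assay. On these data alone, this change amounts to an at least 1.9-fold lower number from compound 3 to compound 4 (0.29 log units; that floor lies within the scatter), and the other two comparisons give an at least 1.9-fold lower number from compound 2 to compound 4 (0.29 log units; that floor lies within the scatter) and an at least 1.9-fold lower number from compound 1 to compound 4 (0.29 log units; that floor lies within the scatter), so each shows only a floor and the true size of the step stays unknown. The steps among the three shorter chains cannot be read because they all meet the same ceiling: the limit of > 128000 nM in this assay, at which 3 of the 4 values shown sit.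

As far as these compounds go, whether a longer chain would bring the number in this assay lower still remains open. So does whether an amine or a carboxylic acid at the end of the chain would keep a measurable value.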